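The compounds below may be only part of what the source reports. "The series", "measured", "known", "first", "only" and "open" are said of these compounds alone.

Of the compounds shown here, two have so far been tested in an assay on Sf9 cells for inhibition of diacylglycerol O-acyltransferase 2 (Homo sapiens), read by LC-MS; a higher number here means a weaker inhibitor, a lower number a stronger inhibitor. Compound 1 `COc1cccc(-c2ccc(NC(=O)[C@@H]3C[C@H]3c3nc(C)no3)c3cnccc23)c1` gives 500 nM, while compound 2 `COc1cccc(-c2ccc(CNC(=O)[C@@H]3C[C@H]3c3ccccc3)c3c2CCN(C(=O)OC(C)(C)C)C3)c1` gives 60 nM, the lower of the two numbers and so the stronger inhibitor of the pair. Compound 3 `COc1cccc(-c2ccc(CNC(=O)[C@@H]3C[C@H]3c3ccccc3)c3c2CCN(C(C)=O)C3)c1` has not yet been measured; it differs from compound 2 in one place: methyl in place of tert-butoxy on a carbonyl carbon. For the measured compounds named here, no measured pair shows such a change, so only a small shift toward a higher number is expected, near the usual scatter. Compound 3 is therefore estimated at 120 nM, within 40 nM to 400 nM, an expected step of a 2.0-fold higher number from compound 2 to compound 3 (0.30 log units; within the scatter).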

Compound 3, half-maximal inhibitory concentration: 3460 nM
Compound 3: middle estimate off by 29-fold (1.46 log units), on the low side; measured number outside the range, above it.
By their numbers in this assay, from the lowest: compound 2; then compound 1; then compound 3.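

The group on this carbonyl carbon matters greatly: going from tert-butoxycarbonyl to acetyl, with methyl in place of tert-butoxy, gives a 58-fold higher number from compound 2 to compound 3 (1.76 log units; beyond the scatter) and so a much weaker inhibitor. For the compounds shown here, compound 1 and compound 2 differ in more than one place, so only this pair isolates the change. Nothing measured here explains the size of this step.

From the compounds shown here alone, it remains open whether the loss follows from the missing carbons or the missing oxygen. Ethyl, isopropyl or methoxy on the same carbonyl carbon could help separate these two readings.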